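Five-membered heteroaryl variation on the shared core

The source may report more compounds than this note shows. Statements on the series, on what has been measured and on what is new or still open speak of the compounds shown alone.

Compound 3 `c1ccc(-c2ccns2)c(OCC2=NCCN2)c1` gives 25.1 nM in a functional assay for activation of Alpha-1D adrenergic receptor (Homo sapiens), read by calcium flux (a lower number here means that less compound is needed, a higher number that more compound is needed for the effect), the larger of the two numbers shown but within the usual scatter of its only neighbour, compound 2 `c1csc(-c2ccccc2OCC2=NCCN2)c1`, which gives 15.9 nM in this assay; a 1.6-fold higher number from compound 2 to compound 3 (0.20 log units; within the scatter). Compound 1 `c1coc(-c2ccccc2OCC2=NCCN2)c1` returns only a limit, < 100000 nM. Because of the limit of < 100000 nM in this assay, at which 1 of the 3 values shown sits, the steps a step that the limit leaves unreadable from compound 1 to compound 2 and a step that the limit leaves unreadable from compound 1 to compound 3 cannot be sized. Compound 4 `Cc1csc(-c2ccccc2OCC2=NCCN2)n1` differs from compound 3 by 4-methyl-1,3-thiazol-2-yl in place of 1,2-thiazol-5-yl on an aromatic carbon. Among the compounds with values here, the one readable step, between the rings of compound 2 and compound 3, stayed within the scatter, while compound 1 shows that a five-membered ring is no guarantee of the effect. The expected step is a 2.4-fold higher number from compound 3 to compound 4 (0.38 log units; beyond the scatter). Compound 4 is estimated at 60 nM, between 10 nM and 400 nM.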

Compound 4, half-maximal effective concentration: < 100000 nM
Compound 4 gave a limit, no number (the forecaster's own chance of this, stated with the estimate: 12%); the middle value is on the limit's open side.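

Compound 4 returns only a limit, so its steps from compound 1, compound 2 and compound 3 cannot be read: the limit of < 100000 nM in this assay, at which 2 of the 4 values shown sit. Still open, from the compounds shown here alone, is whether the limit of compound 4 goes with the methyl group or with the 1,3-thiazol-2-yl ring itself.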